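The source may report more compounds than this note shows. Statements on the series, on what has been measured and on what is new or still open speak of the compounds shown alone.

Of the compounds shown here, three built on one shared core have been measured in an assay (Canis lupus familiaris) for binding affinity to platelet-activating factor receptor (Homo sapiens), read by radioligand binding; on this read-out lower numbers stand for stronger inhibition and higher numbers for weaker inhibition. Compound 1 `COc1ccc(-c2ccc(C(=O)NCCCCc3cccnc3)cc2OC)cc1OC` gives 300 nM. Compound 2 `C=CCc1cc(C(=O)N[C@H](C)CCCc2cccnc2)ccc1-c1ccc(OC)c(OC)c1` gives 80 nM, and compound 3 `CCCc1cc(C(=O)N[C@H](C)CCCc2cccnc2)ccc1-c1ccc(OC)c(OC)c1` gives 50 nM. Compound 3 thus sits at the low end of the three numbers: the step of a 1.6-fold lower number from compound 2 to compound 3 (0.20 log units; within the scatter) lies within the scatter, whereas the gap to compound 1, which differs from compound 3 in two places, is beyond it.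

Compound 4 `COc1ccc(-c2ccc(C(=O)N[C@H](C)CCCc3cccnc3)cc2[N+](=O)[O-])cc1OC` is the next candidate. It differs from compound 3 by nitro in place of propyl on an aromatic carbon. Going by the values given here, only one single-site step has been measured at the place where this change is made, the step of a 1.6-fold lower number from compound 2 to compound 3 (0.20 log units; within the scatter), and it exchanged one chain for another without a shift beyond the scatter. No measured step shows a nitro entering anywhere, so the change to compound 4 has no close precedent among these compounds. The values of compound 1 and compound 3 show that replacements at this place can move the number by a margin beyond the scatter. Compound 4 is therefore expected to give a somewhat higher number, with the step of a 2.0-fold higher number from compound 3 to compound 4 (0.30 log units; within the scatter) estimated to reach only narrowly past the scatter. The estimate for compound 4 is 100 nM, with a range from 30 nM to 400 nM.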

Compound 4, half-maximal inhibitory concentration: 200 nM
Compound 4: middle estimate off by 2.0-fold (0.30 log units), on the low side; the range from low to high includes it.
By their numbers in this assay, from the lowest: compounds 3 and 2 (each within the scatter of the next); then compounds 4 and 1 (each within the scatter of the next).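

In this assay, the place ortho to a 3,4-dimethoxyphenyl group had so far shown only an exchange of one chain for another, with no shift beyond the scatter, but nitro brings the first single-site change there that goes beyond it: a 4.0-fold higher number from compound 3 to compound 4 (0.60 log units; beyond the scatter) and a 2.5-fold higher number from compound 2 to compound 4 (0.40 log units; beyond the scatter). The number at this place therefore does respond to the group on the aromatic carbon, even though propyl and nitro have the same count of heavy atoms and differ in which atoms these are, with nitrogen and oxygen replacing carbon and hydrogen-bond acceptors entering. No measurement here accounts for the rise, so the data give the size of the shift and not its cause.

The compounds shown leave open how an amine, a carboxylic acid or a longer chain such as pentyl would read at this place, and so whether the higher number is particular to nitro or shared by other groups that replace the carbon chain. They also leave open whether the nitro step would hold with the amide side chain of compound 1, which differs from compound 4 in more than one place and so gives no clean comparison.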